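Removing a Methyl Group from a Free Fatty Acid Receptor Agonist

The source may hold more compounds than are shown below. What is called first, only, known or untested is meant among the compounds shown, and "the series" means these compounds.

Measured compounds:
compound 1 `CC#CC(CC(=O)O)c1ccc(OC2CCCc3nc(-c4ccc(C)cc4)sc32)cc1` gives 51 nM
compound 2 `CC(CC(=O)O)c1ccc(Oc2ccc(Cl)cc2Cl)cc1` gives 2480 nM

Of the compounds shown here, two have been measured in a functional assay on CHO cells for agonist activity at Free fatty acid receptor 1 (Homo sapiens), read by FLIPR and calcium flux; on this read-out lower numbers stand for an effect already at smaller amounts and higher numbers for an effect only at larger amounts of compound. Compound 1 carries a longer chain and a bicyclic core; in this assay compound 1 gives 51 nM. Compound 2 is a smaller molecule with a dichlorophenyl ether in place of that core, and in this assay compound 2 gives 2480 nM, the highest of the two numbers shown, well apart from compound 1.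

Compound 3 `O=C(O)CCc1ccc(Oc2ccc(Cl)cc2Cl)cc1` has not yet been measured. It differs from compound 2 in a single place: hydrogen in place of methyl on a saturated chain carbon bound to an aromatic carbon and a saturated chain carbon. The acid-bearing chain is kept, only the branch is gone.

Within the data shown here, no measured pair shows this exact change, so the direction must be estimated from the two compounds alone. Among the measured compounds shown here, the branched chain is present in both measured compounds, and the only available comparison ties a longer branch to the lower number. A modest loss is therefore expected, with the step from compound 2 to compound 3 estimated at a 2.4-fold higher number from compound 2 to compound 3 (0.38 log units; beyond the scatter). For compound 3 the expected value is 6000 nM, with a range from 2000 nM to 20000 nM.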

Compound 3, half-maximal effective concentration: 1360 nM
Beside the measured number, compound 3's estimate is 4.4-fold (0.64 log units) above it, and the stated range ends above it.
By their numbers in this assay, from the lowest: compound 1; then compounds 3 and 2 (each within the scatter of the next).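

In this assay, putting hydrogen in place of methyl on a saturated chain carbon bound to an aromatic carbon and a saturated chain carbon gives a 1.8-fold lower number from compound 2 to compound 3 (0.26 log units; within the scatter), so with the dichlorophenyl ether kept, the two compounds cannot be told apart. Among these compounds, this is the first comparison in which this branch is the only thing that changes, whereas compound 1 and compound 2 differ in more than one place, so their gap could not be assigned to the branch, and the methyl on this chain emerges as a group that can be removed without a change beyond the usual scatter of repeated measurements. No measured property of these compounds is available to explain this result, so the data record only the outcome of the change and not its origin.

As far as these compounds go, the result covers a single pair, so it remains open whether the methyl can also be removed when the core of compound 1 is present. From the compounds shown here alone, it also remains open how an ethyl group, a hydroxyl group or an amine on the same saturated chain carbon would read in this assay.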